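This account rests on a few compounds, and the source may have more. Where it says the series, first, only, none or still open, it means among the compounds named here.

Working notes on the aryl selenocyanate carbamate series

The three measured compounds share the core of compound 1 `CCCCOC(=O)Nc1ccc([Se]C#N)cc1` and differ only in the ester-side chain of the carbamate. In a functional assay on HTB-54 cells (Homo sapiens) for cytotoxicity, read by MTT assay, with a stated time of 72 h (on this read-out lower numbers stand for stronger inhibition of growth and higher numbers for weaker inhibition of growth), compound 1 gives 17200 nM. Compound 2 `CC(C)COC(=O)Nc1ccc([Se]C#N)cc1` gives 27100 nM in this assay, and compound 3 `C=CCOC(=O)Nc1ccc([Se]C#N)cc1` gives 27000 nM. The steps of a 1.6-fold higher number from compound 1 to compound 2 (0.20 log units; within the scatter), a 1.6-fold higher number from compound 1 to compound 3 (0.20 log units; within the scatter) and a 1.0-fold lower number from compound 2 to compound 3 (0.00 log units; within the scatter) all stay within the scatter, so the three chains cannot be told apart on these numbers. On the numbers shown compound 3 sits second highest of the three, nearest compound 2 and furthest from compound 1, both gaps within the scatter.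

Compound 4 `CCOC(=O)Nc1ccc([Se]C#N)cc1` is not yet measured. Against compound 3 the change is methyl in place of vinyl on a saturated chain carbon bound to an oxygen next to a carbonyl group. Going by the values given here, the steps that bear on this place, a 1.6-fold higher number from compound 1 to compound 3 (0.20 log units; within the scatter) and a 1.0-fold lower number from compound 2 to compound 3 (0.00 log units; within the scatter), were within the scatter, and no measured pair exchanges vinyl for methyl here, so no direction is indicated. Compound 4 is therefore expected to give a number close to that of compound 3, with the step of a 1.2-fold lower number from compound 3 to compound 4 (0.07 log units; within the scatter) expected to stay within the scatter. The estimate for compound 4 is 23000 nM, with a range from 10000 nM to 50000 nM.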

Compound 4, concentration for 50% growth inhibition: 24900 nM
Estimate against measurement, compound 4: 1.1-fold (0.03 log units) below; measured number inside the range.
By their numbers in this assay, from the lowest: compounds 1, 4, 3 and 2 (each within the scatter of the next).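

In this assay, going by these compounds alone, the direct exchange of methyl for vinyl on a saturated chain carbon bound to an oxygen next to a carbonyl group, which no earlier pair offered, gives a 1.1-fold lower number from compound 3 to compound 4 (0.04 log units; within the scatter) and so shows no readable effect of this change. Methyl in place of isopropyl gives a 1.1-fold lower number from compound 2 to compound 4 (0.04 log units; within the scatter) and hydrogen in place of ethyl gives a 1.4-fold higher number from compound 1 to compound 4 (0.16 log units; within the scatter) so the ethyl carbamate joins the other three, and the four chains cannot be told apart on these numbers. Nothing at hand explains this flat picture.

The compounds shown leave open whether any group at this place can move the number beyond the scatter. A longer chain, a benzyl group or a chain carrying an amine would test this.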